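From a Five-Membered to a Six-Membered Aromatic Ring

This account rests on a few compounds, and the source may have more. Where it says the series, first, only, none or still open, it means among the compounds named here.

Of the compounds shown here, two built on one shared core have been measured so far in an ADME assay on Caco-2 cells (Homo sapiens) for permeability; on this read-out lower numbers stand for lower permeability and higher numbers for higher permeability. Compound 1 `CN(C)Cc1nccn1-c1ccc(-c2ccc3c(C(N)=O)nn(-c4ccc5onc(N)c5c4)c3c2F)c(F)c1` gives 2.03 10^-6 cm/s, and compound 2 `CN(C)Cc1[nH]ncc1-c1ccc(-c2ccc3c(C(N)=O)nn(-c4ccc5onc(N)c5c4)c3c2F)c(F)c1` gives 1.1 10^-6 cm/s. These two numbers lie within the scatter of each other, so compound 2 cannot be told apart from compound 1 on this read-out.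

Compound 3 `CN(C)Cc1ncccc1-c1ccc(-c2ccc3c(C(N)=O)nn(-c4ccc5onc(N)c5c4)c3c2F)c(F)c1` carries 2-((dimethylamino)methyl)pyridin-3-yl in place of 5-((dimethylamino)methyl)-1H-pyrazol-4-yl on an aromatic carbon. Within the data shown here, only one measured step bears on this exchange, a swap between two other rings that carry the same (dimethylamino)methyl group: a 1.8-fold lower number from compound 1 to compound 2 (0.27 log units; within the scatter). Among the measured compounds shown here, no measured compound holds the new ring, so this single small step is the only guide, and it fixes no direction. A slight rise in this assay is expected, but nothing beyond the scatter. The expected change is a 1.6-fold higher number from compound 2 to compound 3 (0.21 log units; within the scatter). For compound 3 the estimated value is 1.8 10^-6 cm/s, with an expected range from 0.7 10^-6 cm/s to 4.5 10^-6 cm/s.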

Compound 3, apparent permeability: 1.04 10^-6 cm/s
Compound 3: the middle estimate sits 1.7-fold (0.24 log units) above what was measured, and the stated range covers the measured number.
By their numbers in this assay, from the lowest: compounds 3, 2 and 1 (each within the scatter of the next).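

Across this assay, putting 2-((dimethylamino)methyl)pyridin-3-yl in place of 5-((dimethylamino)methyl)-1H-pyrazol-4-yl gives no difference that can be read (a 1.1-fold lower number from compound 2 to compound 3 (0.02 log units; within the scatter)), even though a five-membered aromatic ring with 1 hydrogen-bond donor gives way to a six-membered aromatic ring with 0 hydrogen-bond donors. The comparison with the imidazole-bearing compound points the same way (a 2.0-fold lower number from compound 1 to compound 3 (0.29 log units; within the scatter)), so compounds 1, 2 and 3 cannot be told apart on this read-out, and at this position, para to a large group, three different aromatic rings carrying the same (dimethylamino)methyl group fall within the scatter of one another. The data offer no explanation for this similarity.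

All three compounds keep the (dimethylamino)methyl group, so the compounds shown say nothing about how the number would respond if a primary amine, a carboxylic acid or a longer aminoalkyl chain stood in its place. They also leave open what a phenyl ring, with no nitrogen in the ring, would give here, and whether any exchange at this position can move the number beyond the scatter.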